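The source may hold more compounds than are shown below. What is called first, only, known or untested is meant among the compounds shown, and "the series" means these compounds.

Compound 1 `O=c1[nH]c(=O)n([C@H]2C[C@H](O)[C@@H](CO)O2)cc1C#CCCO` in a functional assay on L1210 cells (Mus musculus) (a higher number here means a weaker inhibitor, a lower number a stronger inhibitor), gives > 1000 ug/mL, which is a limit of the assay and not a measured number. Compound 2 `CCCC/C=C\c1cn([C@H]2C[C@H](O)[C@@H](CO)O2)c(=O)[nH]c1=O` gives 361 ug/mL in this assay. For the measured compounds named here, the one measured step, an at least 2.7-fold lower number from compound 1 to compound 2 (0.44 log units; beyond the scatter), is bounded on one side by the limit of > 1000 ug/mL in this assay, at which 1 of the 2 values shown sits. Compound 3 `Cc1ccc(S(=O)(=O)OCCC#Cc2cn([C@H]3C[C@H](O)[C@@H](CO)O3)c(=O)[nH]c2=O)cc1` differs from compound 1 by (4-methylphenyl)sulfonyl in place of hydrogen on an oxygen on a saturated carbon. Going by the values given here, no measured step alters this oxygen, so the hexenyl-for-hydroxybutynyl step gives no direct guide, and compound 1 itself sits only at a limit. Compound 3 is expected to give 300 ug/mL, within 30 ug/mL to 1000 ug/mL. The expected step is an at least 3.3-fold lower number from compound 1 to compound 3 (0.52 log units; beyond the scatter), with a real chance that only a limit is again reported.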

Compound 3, concentration for 50% inhibition: > 200 ug/mL
Compound 3: only a limit was reported; the forecaster's own chance of this, stated with the estimate: 40%; the middle value does not contradict the limit.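

Compound 1 and compound 3 each give only a limit in this assay, so the step between them cannot be read. As far as these compounds go, whether (4-methylphenyl)sulfonyl in place of hydrogen on this oxygen changes the inhibition at all stays open.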